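The source may hold more compounds than are shown below. What is called first, only, known or untested is meant among the compounds shown, and "the series" means these compounds.

Compound 1, `Nc1scc(CN2CCN(c3ccc(OC(F)(F)F)cc3)CC2)c1C(=O)c1ccc(Cl)cc1`: 1%
Compound 2, `Nc1scc(CN2CCN(c3ccc(C(F)(F)F)cc3)CC2)c1C(=O)c1cccc(C(F)(F)F)c1`: 0%

Both compounds were tested in an assay on CHO cells for displacement of a labelled ligand from adenosine receptor A3 (Homo sapiens), read by scintillation counting, with a stated time of 120 min, tested at 10 uM; a lower number here means less inhibition, a higher number more inhibition at the concentration tested (going by the name of the read-out). Compound 1 gives 1%, and compound 2 gives 0%; the gap between the two falls within the usual scatter, so neither stands apart and both show essentially no displacement at this concentration. Compound 3, `Nc1scc(CN2CCN(c3cccc(F)c3F)CC2)c1C(=O)c1ccc(Cl)cc1`, has not yet been measured. It differs from compound 1 in one place: 2,3-difluorophenyl in place of 4-(trifluoromethoxy)phenyl on an amine nitrogen in a ring. Going by the values given here, with only two near-zero numbers in hand, no step beyond the scatter is expected in this assay in either direction. Compound 3 is therefore estimated at 2% (range -5% to 15%), an expected step of a number 1 percentage points higher from compound 1 to compound 3 (within the scatter).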

Compound 3, a percentage reported as inhibition, at one concentration (the size of the read-out at that concentration, not a potency): 0%
For compound 3 the middle estimate is 2 percentage points above the measured one; the measured number falls inside the stated range.
By their numbers in this assay, from the lowest: compounds 2, 3 and 1 (each within the scatter of the next).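

Going by these compounds alone, the change to 2,3-difluorophenyl on the ring nitrogen gives the first direct comparison at this position: a number 1 percentage points lower from compound 1 to compound 3 (within the scatter) in this assay. The entering group has fewer heavy atoms and no hydrogen-bond acceptor, yet this swap gives no step beyond the scatter. Nothing measured here explains this flat result.

All three compounds carry a substituted phenyl group at this position, and each reads close to zero. From the compounds shown here alone, it remains open whether a pyridine ring, a benzyl group or a simple methyl group on that nitrogen would give any displacement.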